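Compound 2 to compound 4: phenoxy to 3-chlorophenoxy

The source may hold more compounds than are shown below. What is called first, only, known or untested is meant among the compounds shown, and "the series" means these compounds.

In a functional assay on PC-3 cells (Homo sapiens) for cytotoxicity, read by MTT assay, with a stated time of 48 h (on this read-out higher numbers stand for weaker inhibition and lower numbers for stronger inhibition), compound 1 (`COc1ccc(/C=C/C(=O)/C=C/c2cc3ccccc3nc2Oc2ccccc2)cc1OC`) gives > 10000 nM as a limit of the assay. Compound 3 (`COc1ccc(/C=C/C(=O)/C=C/c2cc3ccccc3nc2Oc2ccc(Br)cc2)cc1OC`) gives > 10000 nM as a limit too. Among the measured compounds shown here, compound 2 (`COc1cc(OC)c(OC)cc1/C=C/C(=O)/C=C/c1cc2ccccc2nc1Oc1ccccc1`) gives 7290 nM as the only number in the set. The rest of the series stands at the limit of > 10000 nM in this assay, at which 2 of the 3 values shown sit, in these notes. Compound 4 (`COc1cc(OC)c(OC)cc1/C=C/C(=O)/C=C/c1cc2ccccc2nc1Oc1cccc(Cl)c1`) has chloro in place of hydrogen on an aromatic carbon. The nearest halogen precedent is bromo in place of hydrogen (a step that the two limits leave unreadable from compound 1 to compound 3). The methoxy change gives little more (an at least 1.3-fold lower number from compound 1 to compound 2 (0.13 log units; that floor lies within the scatter)). No step beyond the scatter is expected in this assay, and the estimated step is small (a 1.1-fold higher number from compound 2 to compound 4 (0.04 log units; within the scatter)). Compound 4 is estimated at 8000 nM in this assay, with an expected range from 3500 nM to 15000 nM for this value.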

Compound 4, half-maximal inhibitory concentration: > 10000 nM
Compound 4: no number, only a limit; the forecaster's own chance of this, stated with the estimate: 45%; middle value at least 1.2-fold (0.09 log units) from the limit.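

In this assay, 3-chlorophenoxy in place of phenoxy gives an at least 1.3-fold higher number from compound 2 to compound 4 (0.13 log units; that floor lies within the scatter), and this step has a floor only, so its true size stays unread. Unlike the bromo step between two limits, this halogen step starts from a measured number, and chloro at this place brings no lower number than compound 2 has. With this compound the series sits still more at the limit: the limit of > 10000 nM in this assay, at which 3 of the 4 values shown sit.

The compounds shown leave open whether an amine or a carboxylic acid at this place would give a number rather than a limit. Going by these compounds, whether a longer chain here would do so stays equally open.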